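Compound 3 loses its fluoro group

The compounds below may be only part of what the source reports. "The series", "measured", "known", "first", "only" and "open" are said of these compounds alone.

Measured in an ADME assay on microsomes from liver (Homo sapiens) for metabolic stability, read by LC-MS, with a stated time of 60 min, tested at 1 uM; on this read-out higher numbers stand for fast clearance and lower numbers for slow clearance:
compound 1 `O=C(Nc1ccc(F)c(-c2nc3ncccc3o2)c1)c1cnco1`: 14 mL.min-1.g-1
compound 2 `O=C(Nc1ccc(F)c(-c2nc3ncccc3o2)c1)c1ccoc1`: 154 mL.min-1.g-1
compound 3 `Cc1ccoc1C(=O)Nc1ccc(F)c(-c2nc3ncccc3o2)c1`: 202 mL.min-1.g-1

Compound 3 stands level with compound 2 at the high end of these numbers, as the step of a 1.3-fold higher number from compound 2 to compound 3 (0.12 log units; within the scatter) shows, and far from compound 1. Compound 4 `Cc1ccoc1C(=O)Nc1cccc(-c2nc3ncccc3o2)c1` differs from compound 3 in one place: hydrogen in place of fluoro on an aromatic carbon. The measured steps offer little guidance here. The large steps of an 11-fold higher number from compound 1 to compound 2 (1.04 log units; beyond the scatter) and a 14-fold higher number from compound 1 to compound 3 (1.16 log units; beyond the scatter) both exchange the group on the carbonyl carbon, as does the step between compound 2 and compound 3, so none of them touches the fluoro group. Among the compounds with values here, no measured pair shows what losing it does in this assay. No step beyond the scatter is therefore expected, and no direction can be favoured. The estimate amounts to an expected 1.0-fold lower number from compound 3 to compound 4 (0.00 log units; within the scatter). For compound 4 the expected value is 200 mL.min-1.g-1, with an estimated range of 100 mL.min-1.g-1 to 400 mL.min-1.g-1.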

Compound 4, intrinsic clearance in microsomes: 181 mL.min-1.g-1
The estimate for compound 4 lay 1.1-fold (0.04 log units) above the measured number; measured number inside the range.
By their numbers in this assay, from the lowest: compound 1; then compounds 2, 4 and 3 (each within the scatter of the next).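

In this assay, within the data shown here, hydrogen in place of fluoro on an aromatic carbon gives a 1.1-fold lower number from compound 3 to compound 4 (0.05 log units; within the scatter), the only measured change at this position, since compounds 1, 2 and 3 all carry the fluoro group. With 3-methylfuran-2-yl on the carbonyl carbon, then, losing the fluoro group leaves the number within the scatter. The only steps beyond the scatter among these compounds are still those that exchange 1,3-oxazol-5-yl on the carbonyl carbon for a furan group, and nothing available bears on why the number holds when the fluoro group leaves.

From the compounds shown here alone, whether the same exchange would leave the number in place with 1,3-oxazol-5-yl on the carbonyl carbon, as in compound 1, remains open. Also open, going by these compounds, is what a chlorine atom, a methoxy group or an amine at this place would do.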